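Changing the amide side group of compound 3

The source may hold more compounds than are shown below. What is called first, only, known or untested is meant among the compounds shown, and "the series" means these compounds.

Values in a functional assay on MDA-MB-231 cells (Homo sapiens) for inhibition, read by CellTiter-Glo, with a stated time of 72 h; on this read-out lower numbers stand for higher toxicity in this test and higher numbers for lower toxicity in this test:
Compound 1 `CC1=C(CC(=O)NCCN(C)C)c2cc(F)ccc2/C1=C\c1nc2ccccc2s1` gives 3630 nM
Compound 2 `CC1=C(CC(=O)N2CCN(CCCN(C)C)CC2)c2cc(F)ccc2/C1=C\c1ccc([S+](C)[O-])cc1` gives 46200 nM
Compound 3 `CC1=C(CC(=O)NCCN2CCCC2)c2cc(F)ccc2/C1=C\c1nc2ccccc2s1` gives 3560 nM

Compound 3, at 3560 nM, stands level with compound 1, at 3630 nM, within the usual scatter. Compound 2 shows a clearly higher number, 46200 nM, which here means lower toxicity to the cells.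

The next compound is compound 4 `CC1=C(CC(=O)N2CCN(CCCN(C)C)CC2)c2cc(F)ccc2/C1=C\c1nc2ccccc2s1`. The change is 4-(3-(dimethylamino)propyl)piperazin-1-yl in place of (2-(pyrrolidin-1-yl)ethyl)amino on a carbonyl carbon, so a new group sits on the carbonyl carbon.

Among the compounds with values here, only one measured step is close to this change: a 1.0-fold lower number from compound 1 to compound 3 (0.01 log units; within the scatter). It altered only the end of the side chain and stayed within the scatter, so it is a weak guide to replacing the whole group. Compound 2 carries the same 4-(3-(dimethylamino)propyl)piperazin-1-yl group and gives 46200 nM, but it also differs from compound 4 elsewhere in the structure. Within the data shown here, no measured pair isolates the effect of this exchange, so the expected range stays wide.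

The expected result is a 1.2-fold lower number from compound 3 to compound 4 (0.07 log units; within the scatter), which means no step beyond the scatter is expected in this assay. For compound 4 the estimate is 3000 nM, with an expected range from 1000 nM to 10000 nM.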

Compound 4, half-maximal cytotoxic concentration: 2900 nM
The estimate for compound 4 lay 1.0-fold (0.01 log units) above the measured number, and the stated range covers the measured number.
By their numbers in this assay, from the lowest: compounds 4, 3 and 1 (each within the scatter of the next); then compound 2.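

In this assay, the exchange on the carbonyl carbon gives a 1.2-fold lower number from compound 3 to compound 4 (0.09 log units; within the scatter) and a 1.3-fold lower number from compound 1 to compound 4 (0.10 log units; within the scatter), so replacing the whole side group with the larger 4-(3-(dimethylamino)propyl)piperazin-1-yl group, which also removes the amide hydrogen, produces no change beyond the scatter in this test. With that side group held fixed, the pair that compound 4 completes gives a 16-fold lower number from compound 2 to compound 4 (1.20 log units; beyond the scatter), which places this large difference at another site: the double-bonded chain carbon bound to a double-bonded ring carbon, where compound 4 carries a group with a five-membered aromatic ring and compound 2 a group with only a six-membered aromatic ring of carbon only. No measured evidence is available to explain either result.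

Every side group shown ends in an amine, so it remains open whether a side group ending in a hydroxyl or a carboxylic acid would give a similar number. Within the data shown here, it is also open whether the side group can be exchanged as freely in compounds carrying the aromatic group of compound 2, since that group appears here with only one side group.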